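Nitro in place of amino on the chloro-bearing carbon

This account rests on a few compounds, and the source may have more. Where it says the series, first, only, none or still open, it means among the compounds named here.

Measured so far:
compound 1 `COc1cccc(Nc2nc(Cl)nc3[nH]cnc23)c1` — 1900 nM
compound 2 `COc1cccc(Nc2nc(N)nc3[nH]cnc23)c1` — 27000 nM
compound 3 `Fc1cccc(Nc2nc(Cl)nc3[nH]cnc23)c1` — 7500 nM

All numbers come from an assay for inhibition of cytokinin dehydrogenase 2 (Arabidopsis thaliana); a higher number here means a weaker inhibitor, a lower number a stronger inhibitor. Compound 2 gives the highest of the three: compound 3 sits below it and compound 1 lower still, so compound 2 is the weakest inhibitor measured. The unmeasured compound 4 `COc1cccc(Nc2nc([N+](=O)[O-])nc3[nH]cnc23)c1` differs from compound 2 by nitro in place of amino on an aromatic carbon, on an aromatic carbon of a six-membered aromatic ring with 2 nitrogen, between two ring nitrogen atoms. For the measured compounds named here, the one measured step at this carbon is a 14-fold higher number from compound 1 to compound 2 (1.15 log units; beyond the scatter), a large loss on going from chloro to amino. Going by the values given here, no measured compound carries a nitro group, so the expectation rests only on removing the amino that cost so much. Compound 4 is therefore estimated at 4000 nM (range 900 nM to 18000 nM), an expected 6.8-fold lower number from compound 2 to compound 4 (0.83 log units; beyond the scatter).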

Compound 4, half-maximal inhibitory concentration: 14000 nM
Compound 4: middle estimate off by 3.5-fold (0.54 log units), on the low side; the measured number falls inside the stated range.
By their numbers in this assay, from the lowest: compound 1; then compounds 3, 4 and 2 (each within the scatter of the next, the first and the last beyond it).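

In this assay, nitro in place of amino gives (a 1.9-fold lower number from compound 2 to compound 4 (0.29 log units; within the scatter)), so removing the amino group alone does not bring the number back to that of compound 1. Nitro in place of chloro also gives a step beyond the scatter (a 7.4-fold higher number from compound 1 to compound 4 (0.87 log units; beyond the scatter)), so the loss at this carbon is not confined to amino. No measured evidence bears on this result. Open, from the compounds shown here alone, is whether bromo, methyl or methoxy at this carbon would stay close to compound 1 or to compound 4. Also open, going by these compounds, is whether hydrogen there would match chloro.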